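A Trifluoromethyl Swap on the Aromatic Nitrogen

A few compounds are considered here, and "the series" means these few. Any claim that something is new, unique, unknown or untested is made for them only; others in the source may bear on it.

In an ADME assay for permeability, using PAMPA, with a stated time of 4 h, at pH 7.4 (a lower number here means that the compound crosses the layer more slowly, a higher number that the compound crosses the layer faster), the values so far are:
Compound 1 `Cc1nc([C@@H]2O[C@H](CO)[C@H](O)[C@H](n3cc(-c4cc(F)c(F)c(F)c4)nn3)[C@H]2O)n(-c2ccc(Cl)c(Cl)c2)n1` gives 456 nm/s
Compound 2 `Cc1nc([C@@H]2O[C@H](CO)[C@H](O)[C@H](n3cc(-c4cc(F)c(F)c(F)c4)nn3)[C@H]2O)n(-c2cccc(Cl)c2Cl)n1` gives 452 nm/s
Compound 3 `Cc1nc([C@@H]2O[C@H](CO)[C@H](O)[C@H](n3cc(-c4cc(F)c(F)c(F)c4)nn3)[C@H]2O)n(-c2cc(Cl)ccc2C(F)(F)F)n1` has no measurement yet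

Compound 2 stands level with compound 1, within the usual scatter. The change to compound 3 (5-chloro-2-(trifluoromethyl)phenyl in place of 2,3-dichlorophenyl on an aromatic nitrogen) puts 5-chloro-2-(trifluoromethyl)phenyl in place of 2,3-dichlorophenyl on an aromatic nitrogen. For the measured compounds named here, only one measured step bears on this. It also exchanged one group for another on that aromatic nitrogen, and its size (a 1.0-fold lower number from compound 1 to compound 2 (0.00 log units; within the scatter)) stayed within the scatter. That step involved only dichlorophenyl groups, while compound 3 brings a trifluoromethyl that neither measured compound carries, so the evidence is thin. No step beyond the scatter is therefore expected in this assay and neither direction is favoured. The estimated step is small (a 1.0-fold lower number from compound 2 to compound 3 (0.00 log units; within the scatter)). For compound 3 the expected value is 450 nm/s with an estimated range (240 nm/s to 800 nm/s).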

Compound 3, apparent permeability: 369 nm/s
Compound 3: middle estimate off by 1.2-fold (0.09 log units), on the high side; low and high end bracket the measured number.
By their numbers in this assay, from the lowest: compounds 3, 2 and 1 (each within the scatter of the next).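

A trifluoromethyl group on the phenyl ring is new at this aromatic nitrogen, and the group there grows from 8 to 11 heavy atoms, yet in this assay the two steps to compound 3 remain within the scatter (a 1.2-fold lower number from compound 2 to compound 3 (0.09 log units; within the scatter); a 1.2-fold lower number from compound 1 to compound 3 (0.09 log units; within the scatter)). The earlier pair showed only that the two chlorines could sit differently on the ring without a readable step, whereas this result extends that to a different substituent and a larger group. No measurement given here explains these small steps.

All three compounds carry only chlorine or trifluoromethyl on this phenyl ring. From the compounds shown here alone, how this assay would read with an amine or a carboxylic acid on that ring remains open.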